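One stereocentre redrawn in a small amide series

The source may hold more compounds than are shown below. What is called first, only, known or untested is meant among the compounds shown, and "the series" means these compounds.

Values in a functional assay on MCF7 cells (Homo sapiens) for antiproliferative activity, read by MTT assay, with a stated time of 24 h; a higher number here means a weaker inhibitor, a lower number a stronger inhibitor:
- Compound 1 `CCCCc1oc2ccccc2c1C(=O)c1ccc(OCC(=O)NC(C)C)cc1`: > 50000 nM (a limit of the assay)
- Compound 2 `CCCCc1oc2ccccc2c1C(=O)c1ccc(OCC(=O)Nc2ccccc2)cc1`: 33600 nM
- Compound 3 `CCCCc1oc2ccccc2c1C(=O)c1ccc(OCC(=O)N[C@@H](C)c2ccccc2)cc1`: 17900 nM

The value of compound 1 is a limit and not an exact number. Compound 3 and compound 2 cannot be told apart, with a 1.9-fold lower number from compound 2 to compound 3 (0.27 log units; within the scatter). Compared with the limit, there is an at least 2.7-fold lower number from compound 1 to compound 3 (0.44 log units; beyond the scatter), whereas the floor of an at least 1.4-fold lower number from compound 1 to compound 2 (0.17 log units; that floor lies within the scatter) does not clear the scatter.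

Compound 4 `CCCCc1oc2ccccc2c1C(=O)c1ccc(OCC(=O)N[C@H](C)c2ccccc2)cc1` has not yet been measured. Its difference from compound 3 is the two compounds have the same atoms and bonds and differ only in configuration as drawn: 1 of 1 stereo elements differ; a stereocentre at a saturated chain carbon is drawn S in compound 3 and R in compound 4: the two have the same atoms and bonds, and a stereocentre at a saturated chain carbon is drawn S in compound 3 and R in compound 4.

Among the compounds with values here, no measured step changes configuration alone, so the size of this one can only be judged indirectly. Replacing the whole phenyl of compound 2 gave only a 1.9-fold lower number from compound 2 to compound 3 (0.27 log units; within the scatter), so a small change is expected here too. The expected change is a 1.1-fold higher number from compound 3 to compound 4 (0.05 log units; within the scatter), with no clear direction beyond the scatter. For compound 4, the estimated value in this assay is 20000 nM, with an expected range of 9000 nM to 45000 nM.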

Compound 4, half-maximal inhibitory concentration: 14100 nM
Compound 4: middle estimate off by 1.4-fold (0.15 log units), on the high side; measured number inside the range.
By their numbers in this assay, from the lowest: compounds 4, 3 and 2 (each within the scatter of the next, the first and the last beyond it). At a limit, above all of these: compound 1.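

In this assay, within the data shown here, this is the first step that changes configuration alone, and redrawing the stereocentre of the 1-phenylethyl group gives a 1.3-fold lower number from compound 3 to compound 4 (0.10 log units; within the scatter) and so no detectable preference for either drawn form. Against the phenyl amide there is a 2.4-fold lower number from compound 2 to compound 4 (0.38 log units; beyond the scatter) and this clears the scatter, whereas compound 3 stayed within it against compound 2, so the 1-phenylethyl group's edge over phenyl is modest and sits close to the scatter. Compound 1 stands at a limit of the assay, so an at least 3.5-fold lower number from compound 1 to compound 4 (0.54 log units; beyond the scatter) gives only a floor for replacing isopropyl.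

As far as these compounds go, whether a benzyl group, which has no stereocentre, or a longer chain such as 2-phenylethyl would give similar numbers stays open. So does the effect of an amine or a carboxylic acid on that phenyl ring.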